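Series notes: tert-butyl to isopropyl, compound 4

The compounds below may be only part of what the source reports. "The series", "measured", "known", "first", "only" and "open" are said of these compounds alone.

The shared core appears in compound 1 `CCO/C(O)=C1\C(C)=NC(C)=C([N+](=O)[O-])C1c1cccnc1`, which in a functional assay (cardiac atrium) for agonist activity, with Cavia porcellus as the target (on this read-out lower numbers stand for an effect already at smaller amounts and higher numbers for an effect only at larger amounts of compound), gives 8840 nM. Compound 2 `COCCO/C(O)=C1\C(C)=NC(C)=C([N+](=O)[O-])C1c1cccnc1` gives 49400 nM, and compound 3 `CC1=NC(C)=C([N+](=O)[O-])C(c2cccnc2)/C1=C(\O)OC(C)(C)C` gives 14600 nM. Compound 3 therefore stands second highest of the three numbers; its nearest neighbour is compound 1, with a 1.7-fold higher number from compound 1 to compound 3 (0.22 log units; within the scatter), and its furthest is compound 2, with a 3.4-fold lower number from compound 2 to compound 3 (0.53 log units; beyond the scatter). Within the data shown here, all variation so far sits on the oxygen on an unsaturated carbon, and the one move there that went beyond the scatter is a 5.6-fold higher number from compound 1 to compound 2 (0.75 log units; beyond the scatter).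

Compound 4 `CC1=NC(C)=C([N+](=O)[O-])C(c2cccnc2)/C1=C(\O)OC(C)C` differs from compound 3 by hydrogen in place of methyl on a saturated chain carbon bound to an oxygen on an unsaturated carbon and two saturated chain carbons. Among the measured compounds shown here, two measured steps bear on this, since both alter the group on that oxygen: a 1.7-fold higher number from compound 1 to compound 3 (0.22 log units; within the scatter) lies within the scatter, and a 3.4-fold lower number from compound 2 to compound 3 (0.53 log units; beyond the scatter) is modest. Going from tert-butyl to isopropyl is a smaller change than either of those, so no step beyond the scatter is expected, and the estimated step is a 1.3-fold lower number from compound 3 to compound 4 (0.12 log units; within the scatter). Compound 4 is expected to give 11000 nM, with a range from 5000 nM to 25000 nM.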

Compound 4, half-maximal effective concentration: 28500 nM
For compound 4 the middle estimate is 2.6-fold (0.41 log units) below the measured one; measured number outside the range, above it.
By their numbers in this assay, from the lowest: compounds 1, 3, 4 and 2 (each within the scatter of the next, the first and the last beyond it).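

In this assay, the tert-butyl to isopropyl change gives a 2.0-fold higher number from compound 3 to compound 4 (0.29 log units; within the scatter), and isopropyl in place of 2-methoxyethyl gives a 1.7-fold lower number from compound 2 to compound 4 (0.24 log units; within the scatter), so neither step separates its pair. The step that does stand out is a 3.2-fold higher number from compound 1 to compound 4 (0.51 log units; beyond the scatter), which shows that a single methyl in place of hydrogen on this chain carbon can carry the number beyond the scatter, whereas the tert-butyl of compound 3 remains within it of the ethyl group, at a 1.7-fold higher number from compound 1 to compound 3 (0.22 log units; within the scatter); the numbers therefore do not follow a steady order from ethyl through isopropyl to tert-butyl. Nothing available explains this difference.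

On these data alone, how a longer chain such as n-butyl, or a 2-aminoethyl group, on this oxygen would read remains open. So does the effect of a benzyl group there.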